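The compounds below may be only part of what the source reports. "The series", "measured", "known", "first", "only" and "open" are said of these compounds alone.

Measured so far in a functional assay on MCF7 cells (Homo sapiens) for antiproliferative activity, read by sulforhodamine B assay, with a stated time of 48 h; a higher number here means a weaker inhibitor, a lower number a stronger inhibitor:
Compound 1 `CCCCN1CCN(c2ccc(S(=O)(=O)Oc3ccccc3)cc2)C1=O` gives 8800 nM
Compound 2 `CCCCN1CCN(c2ccc(S(=O)(=O)Oc3cccc(F)c3)cc2)C1=O` gives 310 nM
Compound 3 `CCCCN1CCN(c2ccc(S(=O)(=O)Oc3ccc(OC)c(OC)c3)cc2)C1=O` gives 340 nM

Compound 3 at 340 nM stands level with compound 2 and well under compound 1 on these numbers. The data show (a 1.1-fold higher number from compound 2 to compound 3 (0.04 log units; within the scatter)) for the first comparison and (a 26-fold lower number from compound 1 to compound 3 (1.41 log units; beyond the scatter)) for the second.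

Compound 4 `CCCCN1CCN(c2ccc(S(=O)(=O)Oc3cc(F)cc(F)c3)cc2)C1=O` has not yet been measured. It carries 3,5-difluorophenyl in place of 3,4-dimethoxyphenyl on an oxygen whose other neighbour is the sulfonyl sulfur (3,5-difluorophenyl in place of 3,4-dimethoxyphenyl on an oxygen).

Within the data shown here, three steps bear on this change. Fluoro in place of hydrogen gave a large one (a 28-fold lower number from compound 1 to compound 2 (1.45 log units; beyond the scatter)), and the 3,4-dimethoxyphenyl group gave a large one of its own from the same starting point. Exchanging the two groups moved the number very little. Compound 4 keeps fluoro substitution, like compound 2 at 310 nM in the same assay, so it is expected to sit close to that value. Among the measured compounds shown here, no measured step shows what a further fluoro adds, so the range stays wide on both sides. The expected step (a 1.1-fold lower number from compound 3 to compound 4 (0.05 log units; within the scatter)) is therefore none beyond the scatter. For compound 4 the estimated value is 300 nM (expected range 90 nM to 1000 nM).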

Compound 4, half-maximal inhibitory concentration: 400 nM
Beside the measured number, compound 4's estimate is 1.3-fold (0.12 log units) below it; measured number inside the range.
By their numbers in this assay, from the lowest: compounds 2, 3 and 4 (each within the scatter of the next); then compound 1.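

In this assay, the 3,5-difluorophenyl group on the oxygen whose other neighbour is the sulfonyl sulfur matches the 3,4-dimethoxyphenyl group it replaces (a 1.2-fold higher number from compound 3 to compound 4 (0.07 log units; within the scatter)). It also matches the single-fluoro group of compound 2 (a 1.3-fold higher number from compound 2 to compound 4 (0.11 log units; within the scatter)), so a second fluoro brings no change beyond the scatter, while the large gap to the unsubstituted phenyl of compound 1 remains (a 22-fold lower number from compound 1 to compound 4 (1.34 log units; beyond the scatter)). The large step from phenyl is thus seen with two fluoro groups, with one and with two methoxy groups in compounds 4, 2 and 3, yet nothing available explains why these different groups give matching numbers.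

The compounds shown leave open whether a substituent of another kind on this phenyl ring, such as an amine or a carboxylic acid, or a single methoxy group would stay level with these three or fall back towards compound 1. They also leave open how a longer chain in place of the butyl chain on the shared core would read in this assay.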